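Methoxy for Methylamino: Expected Cytotoxicity of Compound 4

The source may hold more compounds than are shown below. What is called first, only, known or untested is meant among the compounds shown, and "the series" means these compounds.

The compounds measured so far in an ADME assay on PBMC cells (Homo sapiens) for cytotoxicity, with a stated time of 5 days; on this read-out lower numbers stand for stronger inhibition and higher numbers for weaker inhibition:
compound 1 `CNc1nc(Cl)nc2c1ncn2[C@H]1C[C@H](N=[N+]=[N-])[C@@H](CO)O1` gives > 100000 nM
compound 2 `[N-]=[N+]=N[C@H]1C[C@H](n2cnc3c(NCCCCCO)nc(N)nc32)O[C@@H]1CO` gives > 100000 nM
compound 3 `COc1nc(NC2CC2)c2ncn([C@H]3C[C@H](N=[N+]=[N-])[C@@H](CO)O3)c2n1` gives > 100000 nM

None of these three numbers is a true measured value; each is a limit of this assay. For compound 1 the assay reports only such a limit. The same is true of compound 2. It is also true of compound 3. This is summed up in the limit of > 100000 nM in this assay, at which 3 of the 3 values shown sit. Compound 1 therefore stands no higher and no lower than the other two: all three sit at the edge of what this assay can report, and no order among them can be read.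

The still untested compound 4 `COc1nc(Cl)nc2c1ncn2[C@H]1C[C@H](N=[N+]=[N-])[C@@H](CO)O1` differs from compound 1 in a single place: methoxy in place of methylamino on an aromatic carbon. Among the compounds with values here, no pair of measured compounds that differ in one place exists here, so the size of such a change in this assay cannot be read from any measured step. With every measured value resting at the limit (the limit of > 100000 nM in this assay, at which 3 of the 3 values shown sit), the step from compound 1 to compound 4 is expected to be a step that the limit leaves unreadable from compound 1 to compound 4, that is, nothing beyond the usual scatter. Compound 4 is thus expected to give 200000 nM, with a range from 80000 nM to 800000 nM, and most likely to be reported again only as a limit.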

Compound 4, half-maximal inhibitory concentration: > 100000 nM
Compound 4: a limit, no number; the forecaster's own chance of this, stated with the estimate: 90%; the middle value lies beyond the limit too.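

Within the data shown here, compound 4 and compound 1 both sit at a limit in this assay, not at a true number, so no step between them can be read: the limit of > 100000 nM in this assay, at which 4 of the 4 values shown sit. The compounds shown leave open whether methoxy in place of methylamino on an aromatic carbon alters this read-out at all, and whether any order exists among the compounds.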